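The compounds below may be only part of what the source reports. "The series", "measured", "known", "first", "only" and "open" are said of these compounds alone.

Measured so far:
compound 1, `Cc1cc2c(c(N)nn2C)c(=O)[nH]1` — 1220 ug/mL
compound 2, `Cn1nc(N)c2c(=O)[nH]c(-c3ccccc3)cc21` — 76 ug/mL
compound 3, `Cc1cc2nn(-c3ccccc3)c(N)c2c(=O)[nH]1` — 69 ug/mL

In a physicochemical assay for solubility, read by HPLC (a lower number here means a less soluble compound, a higher number a more soluble compound), compound 1 gives 1220 ug/mL. Compound 2 carries phenyl in place of methyl on an aromatic carbon and in this assay gives 76 ug/mL, which amounts to a 16-fold lower number from compound 1 to compound 2 (1.21 log units; beyond the scatter). Compound 3, in this assay at 69 ug/mL, sits with compound 2 within the scatter; how its core differs from the core of compound 1 is not broken down here.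

Compound 4, `Nc1c2c(=O)[nH]c(-c3ccccc3)cc2nn1-c1ccccc1`, is not yet measured. It differs from compound 3 by phenyl in place of methyl on an aromatic carbon, the same change as that made from compound 1 to compound 2, at a place described in the same words. Since the earlier instance showed a 16-fold lower number from compound 1 to compound 2 (1.21 log units; beyond the scatter), a step of comparable size is expected here, a 17-fold lower number from compound 3 to compound 4 (1.24 log units; beyond the scatter), resting on that single prior instance only; whether a second phenyl costs as much again as the first cannot be read from these compounds. Compound 4 is therefore expected to give about 4 ug/mL in this assay, with a plausible range from 1 ug/mL to 15 ug/mL.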

Compound 4, solubility: < 1 ug/mL
Compound 4 gave a limit, no number; the forecaster's own chance of this, stated with the estimate: 10%; middle value at least 4.0-fold (0.60 log units) away from the limit.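

In this assay compound 4 gives < 1 ug/mL, which is a limit of the assay and not a number. The two pairs carrying phenyl in place of methyl on an aromatic carbon step the same way, a 16-fold lower number from compound 1 to compound 2 (1.21 log units; beyond the scatter) and an at least 69-fold lower number from compound 3 to compound 4 (1.83 log units; beyond the scatter), so the direction of the change carries from the core of compound 1 to the core of compound 3 in these two pairs. This does not show a rule for the series, as only two pairs stand behind it, and it does not show how far the second step really reaches, since that step ends in a limit: the limit of < 1 ug/mL in this assay, at which 1 of the 4 values shown sits.

The compounds shown leave open how a group other than phenyl, such as an amine, a carboxylic acid or a longer chain, would read at that aromatic carbon on either core. They also leave open whether the same step would hold on any core beyond these two.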